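Trading Methyl for Fluorine on the Benzamide Ring

The compounds below may be only part of what the source reports. "The series", "measured", "known", "first", "only" and "open" are said of these compounds alone.

Compound 3 `Cc1cc(C)cc(C(=O)Nc2cccc(-c3oc4cc(-c5ccc(F)cc5)ccc4c(=O)c3O)c2)c1` stands second highest among the three numbers in a functional assay on HeLa cells (Homo sapiens) for antiproliferative activity, read by CCK-8 assay, with a stated time of 72 h (on this read-out lower numbers stand for stronger inhibition and higher numbers for weaker inhibition), where compound 3 gives 5540 nM. Compound 1 `O=C(Nc1cccc(-c2oc3cc(-c4ccc(F)cc4)ccc3c(=O)c2O)c1)c1ccc(C(F)(F)F)cc1` gives 17400 nM, and compound 2 `COc1cc(OC)cc(C(=O)Nc2cccc(-c3oc4cc(-c5ccc(F)cc5)ccc4c(=O)c3O)c2)c1` gives 2700 nM. The measured steps that touch this ring are a 2.1-fold higher number from compound 2 to compound 3 (0.31 log units; beyond the scatter) and a 3.1-fold lower number from compound 1 to compound 3 (0.50 log units; beyond the scatter), both modest. Compound 4 `O=C(Nc1cccc(-c2oc3cc(-c4ccc(F)cc4)ccc3c(=O)c2O)c1)c1cc(F)cc(F)c1` arises from compound 3 by 3,5-difluorophenyl in place of 3,5-dimethylphenyl on a carbonyl carbon. Neither measured step introduces fluorine on this ring, so they frame the outcome without settling it; the entering 3,5-difluorophenyl keeps the substitution pattern of compound 3 while bringing fluorine, which only compound 1 carries. A modest rise is therefore expected, a 1.4-fold higher number from compound 3 to compound 4 (0.16 log units; within the scatter). Compound 4 is estimated at 8000 nM, with a range from 3000 nM to 20000 nM.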

Compound 4, half-maximal inhibitory concentration: 3380 nM
Beside the measured number, compound 4's estimate is 2.4-fold (0.37 log units) above it, within the range that was stated.
By their numbers in this assay, from the lowest: compounds 2, 4 and 3 (each within the scatter of the next, the first and the last beyond it); then compound 1.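

In this assay, 3,5-difluorophenyl on the carbonyl carbon gives a 1.6-fold lower number from compound 3 to compound 4 (0.21 log units; within the scatter) and a 1.3-fold higher number from compound 2 to compound 4 (0.10 log units; within the scatter), so fluorine on this ring does not by itself bring the weak number of compound 1. The larger change is a 5.1-fold lower number from compound 1 to compound 4 (0.71 log units; beyond the scatter) and sets compound 1 apart from compound 4. Nothing available here explains these numbers. On these data alone, whether the weak number of compound 1 follows from the trifluoromethyl group itself or from its place on the ring remains open. Also open, as far as these compounds go, is how 3,5-dichlorophenyl or 3,5-bis(trifluoromethyl)phenyl would compare with 3,5-difluorophenyl.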